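Replacing the bromine-bearing ring on a nucleoside-like scaffold

The compounds below may be only part of what the source reports. "The series", "measured", "known", "first", "only" and "open" are said of these compounds alone.

Measured compounds:
- compound 1, `OC[C@H]1O[C@@H](n2cnc3c(NCc4ccccc4Br)ncnc32)[C@H](O)[C@@H]1O`: > 166000 nM
- compound 2, `COc1cccc(CNc2ncnc3c2ncn3[C@@H]2O[C@H](CO)[C@@H](O)[C@H]2O)c1O`: 148000 nM

Compound 1 `OC[C@H]1O[C@@H](n2cnc3c(NCc4ccccc4Br)ncnc32)[C@H](O)[C@@H]1O` was tested in a functional assay on G-361 cells (Homo sapiens) for antiproliferative activity, with a stated time of 72 h; a higher number here means a weaker inhibitor, a lower number a stronger inhibitor. For compound 1 the result is only a limit of the assay, > 166000 nM, not a number. Compound 2 `COc1cccc(CNc2ncnc3c2ncn3[C@@H]2O[C@H](CO)[C@@H](O)[C@H]2O)c1O` gives 148000 nM in this assay, and the step of an at least 1.1-fold lower number from compound 1 to compound 2 (0.04 log units; that floor lies within the scatter) is therefore only a floor that lies within the usual scatter.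

Compound 3 `Cc1cccc(CNc2ncnc3c2ncn3[C@@H]2O[C@H](CO)[C@@H](O)[C@H]2O)c1O` is not yet measured. It differs from compound 1 by the change (2-hydroxy-3-methylphenyl in place of 2-bromophenyl on a saturated chain carbon bound to a nitrogen on an aromatic ring). Within the data shown here, the only measured step that bears on this, an at least 1.1-fold lower number from compound 1 to compound 2 (0.04 log units; that floor lies within the scatter), also exchanges the 2-bromophenyl for a ring carrying a hydroxyl on the same saturated chain carbon bound to a nitrogen on an aromatic ring, and it shows no change beyond the scatter. The expected step of an at least 1.0-fold lower number from compound 1 to compound 3 (0.01 log units; that floor lies within the scatter) is accordingly small. Compound 3 is estimated at 160000 nM, in the range 90000 nM to 300000 nM.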

Compound 3, half-maximal inhibitory concentration: > 166000 nM
Compound 3 gave a limit, no number; the forecaster's own chance of this, stated with the estimate: 50%; at least 1.0-fold (0.01 log units) between middle value and limit.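

In this assay compound 3 gives > 166000 nM, which is a limit of the assay and not a number. Putting methyl in place of methoxy on an aromatic carbon gives an at least 1.1-fold higher number from compound 2 to compound 3 (0.04 log units; that floor lies within the scatter), so this change on the ring has no effect that can be told from the scatter. The step from compound 1 to compound 3 cannot be read, and most of what is shown sits at the edge of what the assay can report: the limit of > 166000 nM in this assay, at which 2 of the 3 values shown sit.

As far as these compounds go, it stays open whether any group on the saturated chain carbon bound to a nitrogen on an aromatic ring can bring a value clearly lower than these. A phenyl ring carrying an amine or a carboxylic acid, or a longer chain, might show whether this place can shift the result in this assay at all.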